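A 4-fluorophenyl variant of compound 3

A few compounds are considered here, and "the series" means these few. Any claim that something is new, unique, unknown or untested is made for them only; others in the source may bear on it.

Compound 3 `CCCc1nc(-c2ccccc2)c(CNCCN2CCN(c3ccccc3C)CC2)o1` gives 51.3% in an assay on HEK293 cells for inhibition of Voltage-dependent T-type calcium channel subunit alpha-1G (Homo sapiens), read by fluorescence, tested at 10 uM (a higher number here means more inhibition at the concentration tested (going by the name of the read-out), a lower number less inhibition), the middle of three numbers that all lie within the scatter of one another; compound 1 `CCCc1nc(-c2ccccc2)c(CNCCN2CCN(c3ccccc3F)CC2)o1` gives 46.5% and compound 2 `CCCc1nc(-c2ccccc2)c(CNCCN2CCN(c3cccc(C(F)(F)F)c3)CC2)o1` gives 56.3%. The measured steps are a number 9.8 percentage points higher from compound 1 to compound 2 (within the scatter), a number 4.8 percentage points higher from compound 1 to compound 3 (within the scatter) and a number 5 percentage points lower from compound 2 to compound 3 (within the scatter), none beyond the scatter. Compound 4 `CCCc1nc(-c2ccccc2)c(CNCCN2CCN(c3ccc(F)cc3)CC2)o1` differs from compound 3 by 4-fluorophenyl in place of 2-methylphenyl on an amine nitrogen in a ring. Within the data shown here, the nearest precedent is compound 1, whose 2-fluorophenyl sits on the same amine nitrogen in a ring, and the steps of a number 4.8 percentage points higher from compound 1 to compound 3 (within the scatter) and a number 9.8 percentage points higher from compound 1 to compound 2 (within the scatter) show that exchanging this aryl group left the inhibition within the scatter. Compound 4 is therefore expected to stay close to the present three, with an estimated step of a number 1.3 percentage points lower from compound 3 to compound 4 (within the scatter). The estimate for compound 4 is 50%, ranging from 38% to 62%.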

Compound 4, a percentage reported as inhibition, at one concentration (the size of the read-out at that concentration, not a potency): 54.1%
Compound 4: the middle estimate sits 4.1 percentage points below what was measured; measured number inside the range.
By their numbers in this assay, from the lowest: compounds 1, 3, 4 and 2 (each within the scatter of the next).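

Moving to 4-fluorophenyl on the amine nitrogen in a ring keeps the inhibition within the scatter of all three earlier aryl groups (a number 2.8 percentage points higher from compound 3 to compound 4 (within the scatter)) (a number 2.2 percentage points lower from compound 2 to compound 4 (within the scatter)) (a number 7.6 percentage points higher from compound 1 to compound 4 (within the scatter)). Among these compounds, the last of these steps adds a comparison the earlier compounds lacked: 4-fluorophenyl and 2-fluorophenyl cannot be told apart at this position in this assay. No evidence is available that bears on this result. The compounds shown leave open how a pyridyl ring or a simple methyl group on this nitrogen would read. They also leave open whether any group here can move the inhibition beyond the scatter.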